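Symmetry Broken: A Phenyl Enters a Diol Ketone

The compounds below may be only part of what the source reports. "The series", "measured", "known", "first", "only" and "open" are said of these compounds alone.

Of the compounds shown here, two have been measured so far. Compound 1 `CC(C)(CO)CCCC(=O)CCCC(C)(C)CO` gives 27000 nM in a functional assay on cells (Hepatocyte, Rattus norvegicus) for inhibition; a higher number here means a weaker inhibitor, a lower number a stronger inhibitor. Compound 2 `CC(C)(CO)CCCCC(=O)CCCCC(C)(C)CO` gives 4000 nM in this assay, the lowest of the two numbers, and its gap to compound 1 lies beyond the scatter. Compound 3 `CC(C)(CO)CCCCC(=O)CCCCC(C)(CO)c1ccccc1` has not yet been measured; it differs from compound 2 by phenyl in place of methyl on a saturated chain carbon bound to three saturated chain carbons. Among the measured compounds shown here, no pair of measured compounds shows what such a change does here, so the expectation rests on compound 2 alone. The estimate for compound 3 in this assay is a step of a 2.0-fold lower number from compound 2 to compound 3 (0.30 log units; within the scatter), a modest drop in the number, though a step in either direction within the same size would not be surprising. Compound 3 is therefore expected to give about 2000 nM, with a range from 500 nM to 10000 nM.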

Compound 3, half-maximal inhibitory concentration: 1000 nM
The estimate for compound 3 lay 2.0-fold (0.30 log units) above the measured number, within the range that was stated.
By their numbers in this assay, from the lowest: compound 3; then compound 2; then compound 1.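

Replacing methyl with phenyl on a saturated chain carbon bound to three saturated chain carbons gives, in this assay, a 4.0-fold lower number from compound 2 to compound 3 (0.60 log units; beyond the scatter) as a modest step beyond the scatter. Among the compounds shown here, this is the first direct reading at this position, and it shows that the position accepts an aromatic ring of six carbons in place of a single carbon without a loss of inhibition. The change also makes the two ends of the molecule different, whereas in compound 1 and compound 2 they match, so the two ends need not be identical for inhibition in these cells.

No measurement at hand gives a reason for this step. From the compounds shown here alone, it remains open whether an ethyl group, a cyclohexyl ring or an amine at this position would give a similar step, so the aromatic ring cannot yet be separated from added size alone.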